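Ring Size Change on the Acrylamide Arm: Solubility Outlook

A few compounds are considered here, and "the series" means these few. Any claim that something is new, unique, unknown or untested is made for them only; others in the source may bear on it.

Measured so far:
- compound 1 `C=CC(=O)N1CCC[C@H](N2C(=O)N(Cc3ccccc3)Cc3cnc(Nc4ccc(N5CCN(C)CC5)cc4OC)nc32)C1`: 129 ug/mL
- compound 2 `C=CC(=O)NCCN1C(=O)N(Cc2ccccc2)Cc2cnc(Nc3ccc(N4CCN(C)CC4)cc3OC)nc21`: 96.7 ug/mL

In a physicochemical assay for solubility, read by HPLC, in phosphate buffer, measured as thermodynamic solubility, with a stated time of 24 h, at pH 6.8 (on this read-out higher numbers stand for higher solubility and lower numbers for lower solubility), compound 1 gives 129 ug/mL and compound 2 gives 96.7 ug/mL. On these two numbers compound 2 holds the lower figure, but a 1.3-fold lower number from compound 1 to compound 2 (0.13 log units; within the scatter), so the two compounds cannot be told apart on this read-out.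

Compound 3 `C=CC(=O)N1CC[C@@H](N2C(=O)N(Cc3ccccc3)Cc3cnc(Nc4ccc(N5CCN(C)CC5)cc4OC)nc32)C1` differs from compound 2 in one place: 1-(vinylcarbonyl)pyrrolidin-3-yl in place of 2-((vinylcarbonyl)amino)ethyl on an amide-type nitrogen in a ring. For the measured compounds named here, the only measured step that bears on this change is the reverse exchange of a cyclic arm for the open chain, and it stayed within the scatter. Returning to a ring, now five-membered, is therefore not expected to move this assay beyond the scatter either. The step of a 1.2-fold higher number from compound 2 to compound 3 (0.09 log units; within the scatter) is estimated to be small, and compound 3 is expected to give 120 ug/mL, with a range from 60 ug/mL to 240 ug/mL.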

Compound 3, solubility: 199 ug/mL
The estimate for compound 3 lay 1.7-fold (0.22 log units) below the measured number; the measured number falls inside the stated range.
By their numbers in this assay, from the lowest: compounds 2, 1 and 3 (each within the scatter of the next, the first and the last beyond it).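

In this assay, for the compounds shown here, the change from 2-((vinylcarbonyl)amino)ethyl to 1-(vinylcarbonyl)pyrrolidin-3-yl gives a 2.1-fold higher number from compound 2 to compound 3 (0.31 log units; beyond the scatter) and is the first step at this amide-type nitrogen to pass beyond the scatter, although only modestly. Swapping the six-membered ring arm for the five-membered one gives a 1.5-fold higher number from compound 1 to compound 3 (0.19 log units; within the scatter) and so does not separate the two ring arms, while compound 1, which also carries a ring, stays within the scatter of the open chain in compound 2, so having a ring is not enough on its own to clear the scatter. No measurement available here explains the step.

The compounds shown leave open how an azetidine ring or a longer chain carrying the same vinylcarbonyl group would behave at this position. They also leave open what the opposite stereocentre of the pyrrolidine arm would give.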